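This account rests on a few compounds, and the source may have more. Where it says the series, first, only, none or still open, it means among the compounds named here.

Measured compounds:
compound 1 `CSc1cccc(CSc2nc(-c3ccc(F)cc3)c(-c3ccncc3)[nH]2)c1` — 550 nM
compound 2 `Fc1ccc(-c2[nH]c(SCc3ccccc3)nc2-c2ccncc2)cc1` — 300 nM
compound 3 `CSc1ccc(CSc2nc(-c3ccc(Cl)cc3)c(-c3ccncc3)[nH]2)cc1` — 2200 nM

In a functional assay (Homo sapiens) for inhibition (on this read-out higher numbers stand for weaker inhibition and lower numbers for stronger inhibition), compound 1 gives 550 nM, the second highest of the three numbers. Compound 2, at 300 nM, sits within the scatter of compound 1, whereas compound 3, at 2200 nM, stands beyond it. Compound 4 `CSc1ccc(O)c(CSc2nc(-c3ccc(F)cc3)c(-c3ccncc3)[nH]2)c1` is the next compound to be measured and differs from compound 1 by hydroxy in place of hydrogen on an aromatic carbon. Among the compounds with values here, no pair of measured compounds shows this change, so nothing here sets its size; the expectation is a step in this assay of no more than the scatter, with no clear direction. The step from compound 1 to compound 4 is thus expected to be a 1.1-fold lower number from compound 1 to compound 4 (0.04 log units; within the scatter). Compound 4 is estimated at 500 nM, with a range from 150 nM to 1600 nM.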

Compound 4, half-maximal inhibitory concentration: 740 nM
Compound 4: the middle estimate sits 1.5-fold (0.17 log units) below what was measured, within the range that was stated.
By their numbers in this assay, from the lowest: compounds 2, 1 and 4 (each within the scatter of the next, the first and the last beyond it); then compound 3.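

Hydroxy in place of hydrogen on an aromatic carbon, ortho to a large group and para to a methylsulfanyl group, gives a 1.3-fold higher number from compound 1 to compound 4 (0.13 log units; within the scatter) in this assay and so stays within the scatter. Within the data shown here, this is the first view of any change at this position, and it shows that adding hydroxy here leaves no readable shift on this read-out. Nothing available explains the result. Going by these compounds, whether a methoxy group or an amine at the same place would also leave the number unchanged remains open.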